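Compound 3: hydroxy in place of methoxy

This account rests on a few compounds, and the source may have more. Where it says the series, first, only, none or still open, it means among the compounds named here.

Measured so far:
compound 1, `COc1cc(-c2nn(-c3cccc(NC(=O)c4cccc(C(F)(F)F)c4)c3)cc2-c2ccncc2)ccc1Cl`, in a functional assay on NCI-H460 cells (Homo sapiens) for inhibition, read by sulforhodamine B assay, with a stated time of 48 h (a higher number here means a weaker inhibitor of growth, a lower number a stronger inhibitor of growth), gives 9270 nM
compound 2, `COc1cc(-c2nn(-c3cccc(NC(=O)Nc4ccc(Cl)c(C(F)(F)F)c4)c3)cc2-c2ccncc2)ccc1Cl`, in this assay gives 4790 nM

Compound 2 and compound 1 differ only at the carbonyl carbon, and their numbers sit within the scatter of each other: the step of a 1.9-fold lower number from compound 1 to compound 2 (0.29 log units; within the scatter) is too small to separate them, so compound 2 stands level with compound 1 on the two numbers available.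

Compound 3, `O=C(Nc1cccc(-n2cc(-c3ccncc3)c(-c3ccc(Cl)c(O)c3)n2)c1)Nc1ccc(Cl)c(C(F)(F)F)c1`, is compound 2 with hydrogen in place of methyl on an oxygen on an aromatic ring. Put one bond further out, methoxy goes to hydroxy, and 4-chloro-3-methoxyphenyl becomes 4-chloro-3-hydroxyphenyl.

Going by the values given here, no measured step touches this place; the only step available, a 1.9-fold lower number from compound 1 to compound 2 (0.29 log units; within the scatter), concerns the group on the carbonyl carbon and leaves the methoxy untouched. With nothing to show that removing the methyl moves the number, the estimate for compound 3 in this assay is set at the value of compound 2, the expected step being a 1.0-fold higher number from compound 2 to compound 3 (0.00 log units; within the scatter), with the range widened for the untested change. Compound 3 is expected to give 4800 nM, between 1500 nM and 16000 nM.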

Compound 3, concentration for total growth inhibition: 4000 nM
For compound 3 the middle estimate is 1.2-fold (0.08 log units) above the measured one; measured number inside the range.
By their numbers in this assay, from the lowest: compounds 3, 2 and 1 (each within the scatter of the next, the first and the last beyond it).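

In this assay, the step at this place is a 1.2-fold lower number from compound 2 to compound 3 (0.08 log units; within the scatter), so hydroxy and methoxy on the 4-chloro-3-substituted phenyl ring cannot be told apart on these numbers. Going by these compounds alone, the earlier step concerned only the group on the carbonyl carbon, so this is the first reading at this oxygen; it shows that the methyl can leave without the number moving beyond the scatter in the urea of compound 2. No measurement at hand speaks to what lies behind this flat reading.

Still open, as far as these compounds go, is whether anything at this place can move the number beyond the scatter, for example an ethoxy or a longer chain on the oxygen, or an amine or a fluorine in place of the hydroxy. Also open, from the compounds shown here alone, is whether the same change from methoxy to hydroxy stays as flat on the amide of compound 1, where the group on the carbonyl carbon is 3-(trifluoromethyl)phenyl.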